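A few compounds are considered here, and "the series" means these few. Any claim that something is new, unique, unknown or untested is made for them only; others in the source may bear on it.

Compound 1 (`FC(F)(F)c1ccc(CSc2nc(Nc3cccc(Cl)c3)c3ccccc3n2)cc1`): 14600 nM in a functional assay on MGC-803 cells (Homo sapiens) for cytotoxicity, read by MTT assay, with a stated time of 72 h; a higher number here means a weaker inhibitor, a lower number a stronger inhibitor.
Compound 2 (`FC(F)(F)c1ccc(CSc2nc(Nc3cccc(Br)c3)c3ccccc3n2)cc1`): 23700 nM in this assay.
Compound 3 (`O=[N+]([O-])c1cccc(Nc2nc(SCc3ccc(C(F)(F)F)cc3)nc3ccccc23)c1`): > 50000 nM in this assay, which is a limit of the assay rather than a number.

Compound 1 and compound 2 sit within the scatter of each other (a 1.6-fold higher number from compound 1 to compound 2 (0.21 log units; within the scatter)). Compound 3 stands apart, at the limit of > 50000 nM in this assay, at which 1 of the 3 values shown sits, the weakest of the three: the step of an at least 3.4-fold higher number from compound 1 to compound 3 (0.53 log units; beyond the scatter) and the step of an at least 2.1-fold higher number from compound 2 to compound 3 (0.32 log units; beyond the scatter) are both beyond the scatter, in the direction of weaker inhibition.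

Compound 4 (`FC(F)(F)c1ccc(CSc2nc(Nc3ccc(C(F)(F)F)cc3)c3ccccc3n2)cc1`) differs from compound 3 by 4-(trifluoromethyl)phenyl in place of 3-nitrophenyl on a nitrogen on an aromatic ring. Within the data shown here, no measured step makes this exchange. What the three measured compounds show is that the two halogen-bearing compounds give numbers while the nitro-bearing compound 3 reaches only the limit. Compound 4 is therefore expected to move back toward the region of compound 1 and compound 2, an estimated step of an at least 2.0-fold lower number from compound 3 to compound 4 (0.30 log units; that floor lies within the scatter). Compound 4 is estimated at 25000 nM, with a range from 8000 nM to 100000 nM, and with a fair chance that the assay again reports only the limit.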

Compound 4, half-maximal inhibitory concentration: 6170 nM
Beside the measured number, compound 4's estimate is 4.1-fold (0.61 log units) above it; the measured number lies below the stated range.
By their numbers in this assay, from the lowest: compound 4; then compounds 1 and 2 (each within the scatter of the next). At a limit, above all of these: compound 3.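

At this place, on a nitrogen on an aromatic ring, 4-(trifluoromethyl)phenyl gives the strongest inhibitor of the four, clearing both halogen-bearing compounds with a 2.4-fold lower number from compound 1 to compound 4 (0.37 log units; beyond the scatter) and a 3.8-fold lower number from compound 2 to compound 4 (0.58 log units; beyond the scatter). Against the nitro-bearing compound the exchange gives an at least 8.1-fold lower number from compound 3 to compound 4 (0.90 log units; beyond the scatter), a step with only a floor. Compound 3 stands at a limit of the assay rather than at a number: the limit of > 50000 nM in this assay, at which 1 of the 4 values shown sits.

Compound 4 changes both the group and its printed position on the phenyl ring relative to compounds 1, 2 and 3, and the compounds shown do not separate these two changes or say why the numbers move. Going by these compounds, how an amine or a carboxylic acid on that phenyl ring would read also remains open.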